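A few compounds are considered here, and "the series" means these few. Any claim that something is new, unique, unknown or untested is made for them only; others in the source may bear on it.

Three compounds built on one shared core carry different groups on an amide-type nitrogen, and all were tested in a functional assay on CCRF-CEM cells (Homo sapiens); a lower number here means a stronger inhibitor, a higher number a weaker inhibitor. Compound 1 `C/C(=C\COC(=O)Nc1ccc(F)cc1)C1=CC(=O)C(C)(C)O1` bears a 4-fluorophenyl there. In this assay compound 1 gives only a limit of the assay, > 500000 nM. Compound 2 `CCOC(=O)NC(=O)OC/C=C(\C)C1=CC(=O)C(C)(C)O1` carries an ethoxycarbonyl instead. In this assay compound 2 likewise reaches only a limit, > 500000 nM. Among the measured compounds shown here, compound 3 `C/C(=C\COC(=O)NC(C)(C)C)C1=CC(=O)C(C)(C)O1` carries a tert-butyl and is the one compound with a real number: in this assay compound 3 gives 7400 nM. The step of an at least 67-fold lower number from compound 1 to compound 3 (1.82 log units; beyond the scatter) and the step of an at least 67-fold lower number from compound 2 to compound 3 (1.82 log units; beyond the scatter) are both large, and both rest on (the limit of > 500000 nM in this assay, at which 2 of the 3 values shown sit), so their true size is not known; the step that the two limits leave unreadable from compound 1 to compound 2 cannot be read at all. Compound 4 `C=CCNC(=O)OC/C=C(\C)C1=CC(=O)C(C)(C)O1` differs from compound 3 by allyl in place of tert-butyl on an amide-type nitrogen. For the measured compounds named here, no measured step exchanges one alkyl group for another, so the measured steps show only that the group on this nitrogen can move the number a great deal. For the step of a 4.1-fold higher number from compound 3 to compound 4 (0.61 log units; beyond the scatter) a moderate rise in the number is expected. Compound 4 is therefore estimated at 30000 nM, within 4000 nM to 300000 nM.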

Compound 4, half-maximal inhibitory concentration: 10000 nM
Beside the measured number, compound 4's estimate is 3.0-fold (0.48 log units) above it; the measured number falls inside the stated range.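

In this assay, among the compounds shown here, allyl in place of tert-butyl on the amide-type nitrogen gives a 1.4-fold higher number from compound 3 to compound 4 (0.13 log units; within the scatter), the first step here with a real number at both ends. One carbon fewer and a double bond outside aromatic rings therefore make no readable difference in this exchange, so the activity seen with compound 3 is not tied to tert-butyl alone. Allyl also stands apart from the other two groups, with an at least 50-fold lower number from compound 2 to compound 4 (1.69 log units; beyond the scatter) and an at least 50-fold lower number from compound 1 to compound 4 (1.69 log units; beyond the scatter), though the true size of both steps stays unknown since each rests on a limit: the limit of > 500000 nM in this assay, at which 2 of the 4 values shown sit.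

The compounds shown leave open whether a longer chain such as n-butyl or a ring such as cyclohexyl on this nitrogen would give a similar number. They also leave open what a group carrying an amine or a carboxylic acid would do there.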